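This account rests on a few compounds, and the source may have more. Where it says the series, first, only, none or still open, it means among the compounds named here.

Measured in an assay on isolated protein for inhibition of Neprilysin (Oryctolagus cuniculus); a lower number here means a stronger inhibitor, a higher number a weaker inhibitor:
compound 1 `O=C(N[C@H](CSCc1ccccc1)C(=O)O)[C@@H](CS)Cc1ccccc1` gives 14 nM; 9 nM (2 entries);
compound 2 `O=C(N[C@@H](CSCc1ccccc1)C(=O)O)[C@@H](CS)Cc1ccccc1` gives 19 nM;
compound 3 `O=C(N[C@H](CSCc1ccccc1)C(=O)O)[C@@H](CS)Cc1ccc(Cl)cc1` gives 3 nM.

Compound 3 stands at the lower end of these numbers: against compound 2 it lies beyond the scatter, and the two entries of compound 1 both sit above it. Compound 1 and compound 2 differ only in the configuration as drawn (the fact that compounds 1 and 2 differ only in the configuration as drawn), and their numbers stay close; compound 1 itself is entered twice (the several entries of compound 1 in this assay, 14 nM; 9 nM (2 entries)).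

Compound 4 `O=C(N[C@H](CSCc1ccccc1)C(=O)O)[C@H](CS)Cc1ccc(Cl)cc1` is not yet measured. It differs from compound 3 thus: the two compounds have the same atoms and bonds and differ only in configuration as drawn: 1 of 2 stereo elements differ; a stereocentre at a saturated chain carbon is drawn S in compound 3 and R in compound 4. This is not the stereocentre that separates compound 1 from compound 2, so that near-flat step offers no direct guide. Some weakening is expected, with a wide range: the step from compound 3 to compound 4 is estimated at a 4.0-fold higher number from compound 3 to compound 4 (0.60 log units; beyond the scatter), putting compound 4 at 12 nM, between 3 nM and 50 nM.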

Compound 4, half-maximal inhibitory concentration: 147 nM
Compound 4: the middle estimate sits 12-fold (1.09 log units) below what was measured; the measured number lies above the stated range.
By their numbers in this assay, from the lowest: compound 3; then compound 2; then compound 4.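

In this assay, the stereocentre at a saturated chain carbon proves highly sensitive: drawing it R rather than S gives a 49-fold higher number from compound 3 to compound 4 (1.69 log units; beyond the scatter), although no atom or bond changes: the fact that compounds 3 and 4 differ only in the configuration as drawn. The other stereocentre behaves differently, with compound 1 at 14 nM; 9 nM (2 entries) and its counterpart compound 2 at 19 nM, so the two stereo elements do not count alike.

The compounds shown leave open whether this configuration matters as much in a compound without the chlorine. They also leave open whether a hydroxamic acid in place of the thiol would depend on it to the same degree.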